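The source may report more compounds than this note shows. Statements on the series, on what has been measured and on what is new or still open speak of the compounds shown alone.

In a functional assay on A2780 cells (Homo sapiens) for inhibition, read by sulforhodamine B assay, with a stated time of 72 h (a higher number here means a weaker inhibitor, a lower number a stronger inhibitor), compound 1 `O=C(NCc1ccc(S(=O)(=O)c2ccccc2)cc1)c1nc2ccncc2s1` gives > 10000 nM, which is a limit of the assay and not a number. Among the compounds with values here, compound 2 `O=C(NCc1ccc(S(=O)(=O)c2ccccc2)cc1)c1ccc2nccn2c1` gives 13 nM, the only true number so far. Within the data shown here, the single measured step, an at least 760-fold lower number from compound 1 to compound 2 (2.88 log units; beyond the scatter), is large and beyond the scatter, and it concerns the group on the carbonyl carbon. Compound 3 `O=C(NCc1ccc(S(=O)(=O)c2cccc(C(F)(F)F)c2)cc1)c1ccc2nccn2c1` keeps the group of compound 2 at that carbon and differs elsewhere: trifluoromethyl in place of hydrogen on an aromatic carbon. The measured step therefore does not bear directly on this change and gives no size for it. Among the measured compounds shown here, with no measured step at this site, no shift in either direction beyond the scatter is expected, and the expected change is a 1.1-fold lower number from compound 2 to compound 3 (0.03 log units; within the scatter). Compound 3 is estimated at 12 nM, with an expected range of 3 nM to 50 nM.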

Compound 3, half-maximal inhibitory concentration: 2 nM
Compound 3: middle estimate off by 6.0-fold (0.78 log units), on the high side, outside the stated range (below it).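

The change of phenyl to 3-(trifluoromethyl)phenyl shows that this assay also responds at a site away from the carbonyl carbon, with a 6.5-fold lower number from compound 2 to compound 3 (0.81 log units; beyond the scatter). The earlier step reported only on the group at the carbonyl carbon, whereas this one adds a second site at which a single change moves the number beyond the scatter, with compound 3 at 2 nM. Nothing measured here gives a cause for this step.

From the compounds shown here alone, it remains open whether another group on this carbon, such as chlorine, methoxy or an amine, would give a similar shift, or whether trifluoromethyl on another carbon of the ring would do so. Going by these compounds, it is also open whether the step would hold with a different group on the carbonyl carbon, since it is read with only one.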